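Swapping Hydroxy for Fluoro in Compound 2

The source may report more compounds than this note shows. Statements on the series, on what has been measured and on what is new or still open speak of the compounds shown alone.

Measured in a functional assay on MV4-11 cells (Homo sapiens) for antiproliferative activity, with a stated time of 48 h; on this read-out higher numbers stand for weaker inhibition and lower numbers for stronger inhibition
Compound 1 `CCCNNC(=O)c1ccc(CNC(=O)c2ccc3ccncc3c2)cc1` gives 74 nM
Compound 2 `CCCNNC(=O)c1ccc(CNC(=O)c2cc3cc(O)ccc3o2)cc1` gives 40 nM
Compound 3 `CCCNNC(=O)c1ccc(CNC(=O)c2cc3cc(Br)ccc3[nH]2)cc1` gives 66.5 nM

These three values lie within the usual scatter of one another, so compound 2 at 40 nM stands level with compound 1 and compound 3, and no ranking can be drawn. Compound 4 `CCCNNC(=O)c1ccc(CNC(=O)c2cc3cc(F)ccc3o2)cc1` has fluoro in place of hydroxy on an aromatic carbon of the shared core. Among the compounds with values here, no measured pair shows this swap directly. Yet compound 1 at 74 nM and compound 3 at 66.5 nM differ more widely from compound 2 and still stay level with it. The estimated 1.5-fold higher number from compound 2 to compound 4 (0.18 log units; within the scatter) therefore stays within the scatter. For compound 4 the expected value is 60 nM (estimated range 25 nM to 140 nM).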

Compound 4, half-maximal inhibitory concentration: 56.5 nM
For compound 4 the middle estimate is 1.1-fold (0.03 log units) above the measured one, within the range that was stated.
By their numbers in this assay, from the lowest: compounds 2, 4, 3 and 1 (each within the scatter of the next).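

In this assay the direct pair gives a 1.4-fold higher number from compound 2 to compound 4 (0.15 log units; within the scatter) and this step lies within the scatter, so on this aromatic carbon fluoro stands level with hydroxy. Fluoro brings no hydrogen-bond donor or acceptor while hydroxy brings one of each, and the earlier compounds, which differ in more than one place, could not show that this swap leaves the read-out level. No evidence at hand explains this result. Still open, going by these compounds, is how an amine, a methoxy group or a carboxylic acid on this carbon would read. Also open, on these data alone, is whether the same swap stays level on another core.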